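Dropping a Fluorine From an Aryl Ring

The source may hold more compounds than are shown below. What is called first, only, known or untested is meant among the compounds shown, and "the series" means these compounds.

Three close relatives sharing one core have so far been tested in an assay on isolated protein for inhibition of tyrosine-protein kinase receptor UFO (Homo sapiens), read by ELISA; on this read-out lower numbers stand for stronger inhibition and higher numbers for weaker inhibition. Compound 1 `Cn1cc(-c2ccc(NC(=O)c3cn(CC4CCCCC4)cc(-c4ccc(F)cc4)c3=O)cc2)c2c(N)ncnc21` gives 2.3 nM. Compound 2 `Cn1cc(-c2ccc(NC(=O)c3cn(CC4CCOCC4)cc(-c4cccc(F)c4)c3=O)cc2)c2c(N)ncnc21` gives 3 nM. Compound 3 `Cc1cc(-c2cn(C)c3ncnc(N)c23)ccc1NC(=O)c1cn(CC2CCOCC2)cc(-c2ccc(F)cc2)c1=O` gives 4 nM. Compound 2 stands in the middle of these three numbers, but its gaps to compound 1 and to compound 3 both fall within the usual scatter of repeated measurements, so none of the three can be called stronger or weaker than another on this evidence.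

The next compound, compound 4 `Cn1cc(-c2ccc(NC(=O)c3cn(CC4CCOCC4)cc(-c4ccccc4)c3=O)cc2)c2c(N)ncnc21`, differs from compound 2 in one place: hydrogen in place of fluoro on an aromatic carbon. Put another way, a 3-fluorophenyl group becomes a plain phenyl group, the changed carbon sitting on an aromatic carbon of a six-membered aromatic ring of carbon only, meta to a large group. Among the compounds with values here, no pair of measured compounds differs by exactly this change, so there is no measured step to lean on. Since the three measured compounds spread so little in this assay, the expectation for compound 4 is a step of a 1.3-fold higher number from compound 2 to compound 4 (0.12 log units; within the scatter), which is no movement beyond the scatter. Compound 4 is therefore estimated at 4 nM, with a likely range from 1.5 nM to 10 nM.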

Compound 4, half-maximal inhibitory concentration: 1 nM
For compound 4 the middle estimate is 4.0-fold (0.60 log units) above the measured one; measured number outside the range, below it.
By their numbers in this assay, from the lowest: compound 4; then compounds 1, 2 and 3 (each within the scatter of the next).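

In this assay, within the data shown here, the change from 3-fluorophenyl to phenyl gives the first single-place step that can be read, and it is a 3.0-fold lower number from compound 2 to compound 4 (0.48 log units; beyond the scatter), a modest move that lies beyond the scatter. This shows that the number responds to what sits on this aromatic carbon, even though the three earlier compounds sat too close together to reveal any such sensitivity, and that the fluoro group is not needed here for a low number, since the plain phenyl group of compound 4 gives the lower number of this pair. No measurement is available that explains why the number falls when the fluoro group gives way to hydrogen.

The compounds shown leave open how a chloro, a methoxy or an amino group on this same carbon would compare with hydrogen and fluoro. They also leave open whether swapping fluoro for hydrogen would give a similar step in compound 1 or compound 3, whose other parts differ from those of compound 2.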